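The source may report more compounds than this note shows. Statements on the series, on what has been measured and on what is new or still open speak of the compounds shown alone.

So far, three compounds on a shared core have been measured in a functional assay on A2780 cells (Homo sapiens) for antiproliferative activity, read by resazurin assay, with a stated time of 72 h (a higher number here means a weaker inhibitor, a lower number a stronger inhibitor), and compound 3 (`Cc1cccc(Cc2n[nH]c3cc(O)c(C(=O)N(C)Cc4ccccc4)cc23)c1`) sits in the middle. Compound 1 (`CN(Cc1ccccc1Br)C(=O)c1cc2c(Cc3ccccc3)n[nH]c2cc1O`) gives the highest number (1200 nM), compound 3 comes second (490 nM), and compound 2 (`CN(Cc1ccccc1Br)C(=O)c1cc2c(Cc3cccc(Cl)c3)n[nH]c2cc1O`) gives the lowest (130 nM).

Compound 4 (`Cc1cccc(Cc2n[nH]c3cc(O)c(C(=O)N(C)Cc4ccccc4Br)cc23)c1`) departs from compound 3 in one place: bromo in place of hydrogen on an aromatic carbon, ortho to a large group (bromo in place of hydrogen on an aromatic carbon). This turns the benzyl on the amide into 2-bromobenzyl.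

Going by the values given here, no measured step isolates this change. Among the compounds with values here, the only step available is a different one, chloro in place of hydrogen on the other benzyl, which gave a 9.2-fold lower number from compound 1 to compound 2 (0.97 log units; beyond the scatter) and so bears on compound 4 only indirectly. Compounds 1 and 2 both already carry the 2-bromobenzyl, and they point in different directions. Compound 2 (130 nM) has a lower number than compound 3, but compound 1 (1200 nM) has a higher one. Compound 4 would have a methyl where compound 2 has its chloro, so it resembles compound 2 most closely, and a moderate move to a lower number seems likely.

The expected step is a 2.5-fold lower number from compound 3 to compound 4 (0.39 log units; beyond the scatter) by this estimate, with real uncertainty. For compound 4 the estimated value is 200 nM with an expected range from 70 nM to 600 nM in this test.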

Compound 4, half-maximal inhibitory concentration: 310 nM
Compound 4: the middle estimate sits 1.6-fold (0.19 log units) below what was measured; the measured number falls inside the stated range.
By their numbers in this assay, from the lowest: compound 2; then compounds 4 and 3 (each within the scatter of the next); then compound 1.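

In this assay the bromo that turns benzyl into 2-bromobenzyl gives a 1.6-fold lower number from compound 3 to compound 4 (0.20 log units; within the scatter) with the methyl-bearing benzyl at the other end held fixed, so on this aromatic carbon the change cannot be told apart from repeat-measurement noise. With 2-bromobenzyl held fixed, changes on the other benzyl give clearer steps: methyl in place of hydrogen gives a 3.9-fold lower number from compound 1 to compound 4 (0.59 log units; beyond the scatter) and methyl in place of chloro gives a 2.4-fold higher number from compound 2 to compound 4 (0.38 log units; beyond the scatter) and so, among these compounds, the changes on that benzyl are the ones that move the number beyond the scatter. Nothing measured here explains why the bromo step is small or why the steps on the other benzyl are larger.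

The small bromo step is known only with the methyl on the other benzyl, so the same change with a chloro there could differ in size. From the compounds shown here alone, it also remains open whether a different group on the same aromatic carbon, such as an amine, a methoxy group or a carboxylic acid, would shift the number by more than the bromo does.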